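Methyl replaces an amino ester side chain on the shared core

The compounds below may be only part of what the source reports. "The series", "measured", "known", "first", "only" and "open" are said of these compounds alone.

Of the compounds shown here, three sharing a core have been measured in a physicochemical assay for solubility, in phosphate buffer, with a stated time of 18 h, at pH 7.4; a higher number here means a more soluble compound, a lower number a less soluble compound. Compound 1 (`Nc1nc(-c2ccccn2)nn1-c1ncnc2cc(N3CCNCC3)c([N+](=O)[O-])cc12`) gives 4000 nM, and compound 2 (`COc1cc2ncnc(-n3nc(-c4cccnc4)nc3N)c2cc1OC`) gives 27000 nM. Compound 3 (`CCOC(=O)CNc1nc(-n2nc(-c3ccccn3)nc2N)c2cc(OC)c(OC)cc2n1`) gives 48000 nM. For the measured compounds named here, this number lies within the scatter of the one for compound 2 and well beyond the scatter from the one for compound 1, so compound 3 stands with compound 2 at the upper end of this small set.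

Compound 4 (`COc1cc2nc(C)nc(-n3nc(-c4ccccn4)nc3N)c2cc1OC`) has methyl in place of ((ethoxycarbonyl)methyl)amino on an aromatic carbon, between two ring nitrogen atoms: methyl in place of ((ethoxycarbonyl)methyl)amino on an aromatic carbon. Going by the values given here, no measured pair isolates this change. The nearest guide is compound 2, which also lacks the ((ethoxycarbonyl)methyl)amino group and gives 27000 nM, although it differs from compound 4 elsewhere as well. A modest fall in this assay is therefore expected, close to the edge of the scatter. The expected change is a 2.2-fold lower number from compound 3 to compound 4 (0.34 log units; beyond the scatter). For compound 4 the estimated value is 22000 nM, with an expected range from 7000 nM to 60000 nM.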

Compound 4, solubility: 16000 nM
For compound 4 the middle estimate is 1.4-fold (0.14 log units) above the measured one; measured number inside the range.
By their numbers in this assay, from the lowest: compound 1; then compounds 4, 2 and 3 (each within the scatter of the next, the first and the last beyond it).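

For the compounds shown here, replacing ((ethoxycarbonyl)methyl)amino with methyl on the aromatic carbon between two ring nitrogen atoms gives, in this assay, a 3.0-fold lower number from compound 3 to compound 4 (0.48 log units; beyond the scatter), the first step in this set that isolates a single change. It shows that this position alone can move the read-out beyond the scatter, although the step is modest for an exchange of 7 heavy atoms for 1. Nothing available explains the size or direction of this step.

From the compounds shown here alone, it remains open whether the step follows from the ester, the linking amino nitrogen or the whole chain, and how a carboxylic acid, a simple amine or a longer alkyl chain at this position would read in this assay. The compounds shown also leave open whether the same exchange would give a similar step on other substituted versions of the shared core.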